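A few compounds are considered here, and "the series" means these few. Any claim that something is new, unique, unknown or untested is made for them only; others in the source may bear on it.

Measured compounds:
Compound 1, `O=S(=O)(Nc1ccc(-c2nc3ccccc3o2)cc1)c1ccccc1C(F)(F)F`: 74000 nM
Compound 2, `O=S(=O)(Nc1ccc(-c2nc3cc(NS(=O)(=O)c4ccccc4O)ccc3o2)cc1)c1ccccc1O`: 18000 nM
Compound 3, `Cc1ccccc1S(=O)(=O)Nc1ccc(-c2nc3ccccc3o2)cc1`: 85000 nM

In an assay on cells for inhibition of HSP60/HSP10 (Homo sapiens), with a stated time of 60 min (a lower number here means a stronger inhibitor, a higher number a weaker inhibitor), compound 3 gives the highest of the three numbers, but the step of a 1.1-fold higher number from compound 1 to compound 3 (0.06 log units; within the scatter) is within the scatter, so the two are not distinguishable as inhibitors. Going by the values given here, compound 2 carries a second sulfonamide and differs from compound 3 in several places, so no single step links the two. In this assay compound 2 gives 18000 nM, a lower number than that of compound 3 by a margin beyond the scatter.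

Compound 4 is `O=S(=O)(Nc1ccc(-c2nc3ccccc3o2)cc1)c1cccc(F)c1`, and the change from compound 3 is 3-fluorophenyl in place of 2-methylphenyl on a sulfonyl sulfur. Among the compounds with values here, the only measured step that bears on it is the swap of substituents on that same ring, from compound 1 to compound 3, which moved the number by a 1.1-fold higher number from compound 1 to compound 3 (0.06 log units; within the scatter) and stayed within the scatter. On this basis, compound 4 is expected to give a number close to that of compound 3, with the expected step of a 1.1-fold lower number from compound 3 to compound 4 (0.03 log units; within the scatter) not beyond the scatter in either direction. The estimate for compound 4 in this assay is 80000 nM, with a range from 30000 nM to 200000 nM.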

Compound 4, half-maximal inhibitory concentration: 71000 nM
The estimate for compound 4 lay 1.1-fold (0.05 log units) above the measured number, within the range that was stated.
By their numbers in this assay, from the lowest: compound 2; then compounds 4, 1 and 3 (each within the scatter of the next).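

In this assay, putting 3-fluorophenyl in place of 2-methylphenyl on a sulfonyl sulfur gives a 1.2-fold lower number from compound 3 to compound 4 (0.08 log units; within the scatter), so this step, like the earlier one, stays within the scatter. The earlier step exchanged methyl for trifluoromethyl and kept the number in the group's name, whereas this one alters both the substituent and that number, and the result is still not distinguishable from compound 3 as an inhibitor. Nothing measured here offers an explanation for this result.

On these data alone, it remains open whether a group of another kind on this ring, such as an amine or a carboxylic acid, would produce a step beyond the scatter. Compound 2, at 18000 nM, differs from the others in several places, so the compounds shown cannot tell whether its number goes with the second sulfonamide, with the hydroxyl groups, or with both together.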